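Replacing a piperidine substituent on the pyridine of compound 2

This account rests on a few compounds, and the source may have more. Where it says the series, first, only, none or still open, it means among the compounds named here.

Measured compounds:
compound 1 `CC(C(=O)NCc1ccc(C(F)(F)F)nc1)c1ccc(NS(C)(=O)=O)c(F)c1` in a functional assay on CHO-K1 cells for antagonist activity at transient receptor potential cation channel subfamily V member 1 (Homo sapiens), read by FLIPR; on this read-out higher numbers stand for weaker inhibition and lower numbers for stronger inhibition: "not active" (no number reported)
compound 2 `CC(C(=O)NCc1ccc(C(F)(F)F)nc1N1CCC(C)(C)CC1)c1ccc(NS(C)(=O)=O)c(F)c1` in this assay: 8 nM

Compound 1 carries no substituent on the ring carbon next to the pyridine nitrogen, and in this assay compound 1 is reported as "not active" (no number reported) without a number. Compound 2 bears the 4,4-dimethylpiperidin-1-yl group at that position and in this assay compound 2 gives 8 nM, the only numerical result in this set; it therefore stands alone, with compound 1 giving no number to place beside it.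

Compound 3 `CC(C(=O)NCc1ccc(C(F)(F)F)nc1N1CCC(CN(C)C)CC1)c1ccc(NS(C)(=O)=O)c(F)c1` is the unmeasured member. It keeps the whole of compound 2 except for the change (4-((dimethylamino)methyl)piperidin-1-yl in place of 4,4-dimethylpiperidin-1-yl on an aromatic carbon). Within the data shown here, no step between two measured compounds is available to calibrate this change; the only anchor is the value of compound 2. The account expects a modest step in this assay toward weaker inhibition, of a size that may exceed the scatter but not by much, and this is the step of a 3.8-fold higher number from compound 2 to compound 3 (0.57 log units; beyond the scatter) that the estimate implies. For compound 3 the estimated value in this assay is 30 nM, with a range from 8 nM to 120 nM.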

Compound 3, half-maximal inhibitory concentration: 426 nM
Compound 3: the middle estimate sits 14-fold (1.15 log units) below what was measured; measured number above the stated range.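

In this assay, exchanging 4,4-dimethylpiperidin-1-yl for 4-((dimethylamino)methyl)piperidin-1-yl on this aromatic carbon, next to the ring nitrogen, gives a 53-fold higher number from compound 2 to compound 3 (1.73 log units; beyond the scatter) and is a large step. Compound 1 and compound 2 showed only that a substituent here can go with a measurable number, whereas this pair shows that the number also depends heavily on what the six-membered ring carries, even though that ring stays in place. Compound 3 still gives a number, so this change weakens inhibition without giving the "not active" report of compound 1, and nothing shown here offers a measurement that accounts for the size of the step.

The compounds shown leave open whether the step follows the dimethylamino group itself, its methylene link, or the absence of the two methyl groups of compound 2. From the compounds shown here alone, a piperidine carrying a plain ethyl chain or a hydroxymethyl group in place of the dimethylaminomethyl group, or a morpholine in place of the whole piperidine, would be needed to separate these readings, and how far the position tolerates such groups remains unknown.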